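The source may report more compounds than this note shows. Statements on the series, on what has been measured and on what is new or still open speak of the compounds shown alone.

Compound 1 `Cc1occc1-c1nnc2sc(CCCc3ccccc3)nn12`: 41%
Compound 2 `Fc1ccc(-c2nnc3sc(/C=C/c4ccco4)nn23)cc1`: 40%
Compound 3 `Fc1cccc(-c2nnc3sc(CCc4ccccc4)nn23)c1`: 50%

All three were tested in an assay for inhibition of histone-lysine N-methyltransferase, H3 lysine-79 specific (Homo sapiens), read by scintillation counting, with stated times of 15 min and 60 min, tested at 100 uM, in the presence of a further agent that is not named here; on this read-out lower numbers stand for a weaker effect and higher numbers for a stronger effect at the one concentration tested. Compound 3 gives the highest of the three numbers, yet compound 1 sits within the usual scatter of it, and compound 2 does too, so the three cannot truly be ordered. Compound 4 `Cc1occc1-c1nnc2sc(CCc3ccccc3)nn12` has not yet been measured. It differs from compound 3 in one place: 2-methylfuran-3-yl in place of 3-fluorophenyl on an aromatic carbon. Compound 1 already carries the same 2-methylfuran-3-yl group and gives a number within the scatter of compound 3. Going by the values given here, no measured step isolates this change, so no movement beyond the scatter is expected; the expected step is a number 6 percentage points lower from compound 3 to compound 4 (within the scatter). Compound 4 is estimated at 44%, within 25% to 62%.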

Compound 4, a percentage reported as inhibition, at one concentration (the size of the read-out at that concentration, not a potency): 27%
Estimate against measurement, compound 4: 17 percentage points above, and the stated range covers the measured number.
By their numbers in this assay, from the lowest: compound 4; then compounds 2, 1 and 3 (each within the scatter of the next).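

In this assay, 2-methylfuran-3-yl in place of 3-fluorophenyl on the aromatic carbon gives a number 23 percentage points lower from compound 3 to compound 4 (beyond the scatter) and so shows that this position responds to the swap. With 2-methylfuran-3-yl kept, phenyl in place of benzyl on the saturated chain gives a number 14 percentage points lower from compound 1 to compound 4 (beyond the scatter) as well, so the chain also matters with this group. Open, going by these compounds, is whether the chain change would do the same with 3-fluorophenyl, and how a plain phenyl or a pyridine ring would fare at the aromatic carbon. Nothing available here explains either step.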